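Chain Extension and Cytotoxicity in Three Measured Compounds

This account rests on a few compounds, and the source may have more. Where it says the series, first, only, none or still open, it means among the compounds named here.

Compound 1 `CC[C@@H](CCn1cncn1)c1ccc(F)cc1`, compound 2 `CCC[C@H](CCn1cncn1)c1ccccc1` and compound 3 `CCC[C@@H](CCn1cncn1)c1ccc(F)cc1` have all been tested in an ADME assay on RD cells (Homo sapiens) for cytotoxicity, read by MTT assay, with a stated time of 3 days; on this read-out higher numbers stand for lower toxicity in this test and lower numbers for higher toxicity in this test. In this assay compound 1 gives 91.6 ug/mL, compound 2 gives 63.1 ug/mL and compound 3 gives 56.9 ug/mL. Compound 3 differs from compound 1 by methyl in place of hydrogen on a saturated chain carbon, three bonds along the chain from an aromatic carbon, and that change produced a step of a 1.6-fold lower number from compound 1 to compound 3 (0.21 log units; within the scatter). Compound 4 `CCCC[C@H](CCn1cncn1)c1ccccc1` has not yet been measured; it differs from compound 2 by methyl in place of hydrogen on a saturated chain carbon, four bonds along the chain from an aromatic carbon. Going by the values given here, this is the same kind of change as the one from compound 1 to compound 3, though it sits one bond further out, four bonds along the chain from an aromatic carbon instead of three. The difference between the cores of compound 1 and compound 2 is not broken down here. Because the measured step of a 1.6-fold lower number from compound 1 to compound 3 (0.21 log units; within the scatter) stayed within the scatter, compound 4 is expected to show a step of a 1.1-fold lower number from compound 2 to compound 4 (0.06 log units; within the scatter). The estimate for compound 4 in this assay is 55 ug/mL, with an expected range from 30 ug/mL to 100 ug/mL.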

Compound 4, half-maximal cytotoxic concentration: 48.3 ug/mL
Compound 4: middle estimate off by 1.1-fold (0.06 log units), on the high side, and the stated range covers the measured number.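

In this assay, the methyl that turns propyl into butyl, four bonds along the chain from an aromatic carbon, goes with a 1.3-fold lower number from compound 2 to compound 4 (0.12 log units; within the scatter). Set beside the earlier chain extension, the step carries over from one core to the other as far as this test can tell: the same change on two cores in this assay, a 1.6-fold lower number (0.21 log units; within the scatter) from compound 1 to compound 3 and a 1.3-fold lower number (0.12 log units; within the scatter) from compound 2 to compound 4, 1.2-fold (0.09 log units) apart, within the scatter of two such steps On both cores, then, one more methyl gives no step that stands clear of the usual scatter, but this does not show a real shared effect: either step could be repeat noise, and the added methyl sits at a different place along the chain in each pair.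

The compounds shown leave open whether a longer chain than butyl, or a chain ending in an amine or a carboxylic acid, would give a step beyond the scatter. They also leave open whether such a larger step would carry over between the two cores.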